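The source may report more compounds than this note shows. Statements on the series, on what has been measured and on what is new or still open speak of the compounds shown alone.

All three measured compounds share one core and were tested in a functional assay on Right cardiac atrium for agonist activity at histamine H2 receptor (Cavia porcellus), with a stated time of 30 min, in the presence of a further agent that is not named here; a higher number here means that more compound is needed for the effect, a lower number that less compound is needed. Compound 1, `Cc1nc(N)sc1CCCN/C(N)=N/C(=O)NC(C)c1ccc(Br)cc1`, gives 55 nM. Compound 2, `Cc1nc(N)sc1CCCN/C(N)=N/C(=O)NC(c1ccccc1)C(C)C`, gives 34.7 nM, the lowest of the three numbers, although the number for compound 1 lies within the usual scatter of it, so these two cannot be ranked against each other. Compound 3, `Cc1nc(N)sc1CCCN/C(N)=N/C(=S)N[C@@H](C)c1ccccc1`, gives 224 nM in this assay, a number that stands beyond the scatter above that of compound 2.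

Compound 4, `Cc1nc(N)sc1CCCN/C(N)=N/C(=O)NC(c1ccccc1)c1ccccc1`, has not yet been measured. It differs from compound 2 in one place: phenyl in place of isopropyl on a saturated chain carbon bound to an amide-type nitrogen and an aromatic carbon. Among the measured compounds shown here, no measured pair in this set shows the effect of this particular exchange, so the expectation rests on compound 2 itself and on compound 1, whose 55 nM lies within the scatter of compound 2 despite a different group in that same place. On that basis the step of a 1.2-fold lower number from compound 2 to compound 4 (0.06 log units; within the scatter) is expected to stay within the scatter of repeated measurements, with no direction that can be called from the data at hand. For compound 4 the estimated value in this assay is 30 nM, with a likely range from 12 nM to 80 nM.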

Compound 4, half-maximal effective concentration: 39.8 nM
For compound 4 the middle estimate is 1.3-fold (0.12 log units) below the measured one; the range from low to high includes it.
By their numbers in this assay, from the lowest: compounds 2, 4 and 1 (each within the scatter of the next); then compound 3.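

In this assay, phenyl in place of isopropyl on a saturated chain carbon bound to an amide-type nitrogen and an aromatic carbon gives a 1.1-fold higher number from compound 2 to compound 4 (0.06 log units; within the scatter), so compound 2 and compound 4 cannot be told apart. Among the compounds shown here, this pair is the first direct reading of this exchange: a group with 3 heavy atoms and no ring gives way to one with 6 heavy atoms and a six-membered aromatic ring of carbon only, and the two numbers remain within the scatter of each other. Nothing shown here gives a reason for this result.

Both groups in this pair are carbon only, with 0 hydrogen-bond donors and 0 hydrogen-bond acceptors, so the pair says nothing about how a group holding an amine or a carboxylic acid would read at this place. It also leaves open whether a longer chain, such as n-butyl, or a larger ring system, such as naphthyl, would still give a number within the scatter of compound 2.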